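Methoxy Placement on the Aryl Ring of Compound 1

A few compounds are considered here, and "the series" means these few. Any claim that something is new, unique, unknown or untested is made for them only; others in the source may bear on it.

Measured compounds:
compound 1 `CC(C)CCn1ccc(-c2ccccc2)c(C#N)c1=O` gives 8510 nM
compound 2 `COc1ccc(-c2ccn(CCC(C)C)c(=O)c2C#N)cc1` gives 1150 nM
compound 3 `COc1cccc(-c2ccn(CCC(C)C)c(=O)c2C#N)c1` gives 3170 nM

Within this small set compound 1 stands highest in a functional assay on CHO cells for positive allosteric modulation of metabotropic glutamate receptor 2 (Homo sapiens), read by scintillation counting and GTPgammaS binding, with a stated time of 30 min; on this read-out lower numbers stand for an effect already at smaller amounts and higher numbers for an effect only at larger amounts of compound; its nearest neighbour is compound 3 and its furthest is compound 2, both beyond the scatter. The step to compound 4 `COc1ccccc1-c1ccn(CCC(C)C)c(=O)c1C#N` is methoxy in place of hydrogen on an aromatic carbon, the new group sitting on a six-membered aromatic ring of carbon only, ortho to a large group. Within the data shown here, two measured steps bear on it: the same exchange at one ring position gave a 7.4-fold lower number from compound 1 to compound 2 (0.87 log units; beyond the scatter), and at another it gave a 2.7-fold lower number from compound 1 to compound 3 (0.43 log units; beyond the scatter). Both lowered the number, though by different amounts, so a modest lowering is expected for compound 4 as well, nearer the smaller of the two because the step from compound 1 to compound 3 a 2.7-fold lower number from compound 1 to compound 3 (0.43 log units; beyond the scatter) shows how much the gain can shrink with placement. Compound 4 is therefore estimated at 3000 nM, with a range from 1000 nM to 9000 nM, an expected step of a 2.8-fold lower number from compound 1 to compound 4 (0.45 log units; beyond the scatter).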

Compound 4, half-maximal effective concentration: > 10000 nM
Compound 4 was reported as a limit (the forecaster's own chance of this, stated with the estimate: 5%); at least 3.3-fold (0.52 log units) between middle value and limit.
By their numbers in this assay, from the lowest: compound 2; then compound 3; then compound 1. At a limit, above all of these: compound 4.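

The value for compound 4 in this assay is a limit of the assay and not a number: the limit of > 10000 nM in this assay, at which 1 of the 4 values shown sits. It shows that placement can cancel the gain from this exchange: methoxy in place of hydrogen lowered the number in compound 2 and compound 3, but when the methoxy sits ortho to a large group, the reading is an at least 1.1-fold higher number from compound 1 to compound 4 (0.07 log units; that floor lies within the scatter). That floor does not establish a real rise over compound 1, yet compound 4 goes against the lowering seen in the other two.

As far as these compounds go, how far compound 4 lies beyond its limit remains open. Also open, from the compounds shown here alone, is whether this outcome is specific to methoxy or would recur with fluorine, a methyl group or a hydroxyl group on the same aromatic carbon.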